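A few compounds are considered here, and "the series" means these few. Any claim that something is new, unique, unknown or untested is made for them only; others in the source may bear on it.

Measured so far:
- compound 1 `Nc1nc(-c2ccccn2)nn1-c1ncnc2ccccc12`
- compound 2 `COc1ccc(-c2nc(N)n(-c3ncnc4ccccc34)n2)cc1`
- compound 3 `Nc1cc2c(-n3nc(-c4ccccn4)nc3N)ncnc2cc1Cl`

In an assay on MCF7 cells for inhibition of Serine-protein kinase ATM (Homo sapiens), read by immunofluorescence, with a stated time of 1 h (a lower number here means a stronger inhibitor, a higher number a weaker inhibitor), compound 1 gives > 40000 nM, a limit of the assay and not a number. Compound 2 gives > 40000 nM, also a limit. Compound 3 gives > 40000 nM, again a limit. The step that the two limits leave unreadable from compound 1 to compound 2 cannot be read because both ends are limits. Compound 3 therefore stands where the whole set stands, at the limit of > 40000 nM in this assay, at which 3 of the 3 values shown sit.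

Compound 4 `COc1cc2ncnc(-n3nc(-c4ccccn4)nc3N)c2cc1N` differs from compound 3 by methoxy in place of chloro on an aromatic carbon. For the measured compounds named here, no measured step touches this position, and the one step that exists is unreadable, so nothing points to a change beyond the scatter in this assay. Compound 4 is expected to remain at the limit, a step of a number no higher from compound 3 to compound 4 (the limit leaves the size open), with an estimate of 40000 nM between 10000 nM and 100000 nM.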

Compound 4, half-maximal inhibitory concentration: > 40000 nM
Compound 4 was reported as a limit; the forecaster's own chance of this, stated with the estimate: 80%; the middle value sits exactly at the limit.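

In this assay, for the compounds shown here, compound 4 gives > 40000 nM, a limit and not a number, so no step from compound 3 to compound 4 can be read. The compounds shown leave open which change, if any, would bring a value off the limit: the limit of > 40000 nM in this assay, at which 4 of the 4 values shown sit.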